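The source may hold more compounds than are shown below. What is called first, only, known or untested is meant among the compounds shown, and "the series" means these compounds.

Measured so far:
compound 1, `O=c1[nH]c(=O)n(CCC(CO)CO)cc1-c1ccco1`: > 100000 nM
compound 2, `O=c1[nH]c(=O)n(CCC(CO)CO)cc1C#Cc1ccc(Br)cc1`: > 100000 nM

Both values come from a functional assay on SW-620 cells (Homo sapiens) for antiproliferative activity, read by MTT assay, with a stated time of 72 h; a higher number here means a weaker inhibitor, a lower number a stronger inhibitor. For compound 1 the value > 100000 nM is a limit of the assay rather than a measured number. For compound 2 the value > 100000 nM is likewise only a limit. For the measured compounds named here, compound 2 therefore stands at the edge of what the assay can report, as the limit of > 100000 nM in this assay, at which 2 of the 2 values shown sit, shows, and with both compounds at a limit no step between measured compounds can be given. Compound 3, `O=c1[nH]c(=O)n(CCC(CO)CO)cc1C#CC1CC1`, differs from compound 2 in one place: cyclopropyl in place of 4-bromophenyl on a triple-bonded carbon. Going by the values given here, with no measured step to guide the direction, the expected change is a step that the limit leaves unreadable from compound 2 to compound 3, which is no step beyond the scatter. Compound 3 is accordingly expected to give about 150000 nM in this assay, with a range from 40000 nM to 500000 nM, and it is most likely to be reported only as a limit as well.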

Compound 3, half-maximal inhibitory concentration: > 100000 nM
Compound 3 ended at the assay's limit; the forecaster's own chance of this, stated with the estimate: 85%; the middle value lies beyond the limit too.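

For the compounds shown here, compound 3 gives > 100000 nM as a limit and not a number, so no step from compound 1 or compound 2 to compound 3 can be read: the limit of > 100000 nM in this assay, at which 3 of the 3 values shown sit. The compounds shown leave open which group on the shared core, if any, would give in this assay a measured number rather than a limit.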